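The compounds below may be only part of what the source reports. "The series", "measured", "known", "first", "only" and "open" are said of these compounds alone.

Compounds measured in a functional assay on A549 cells (Homo sapiens) for antiproliferative activity, read by MTT assay; a higher number here means a weaker inhibitor, a lower number a stronger inhibitor:
compound 1 `FC(F)(F)Oc1ccc(-c2cc(CN(c3ncccn3)c3nc4ccccc4s3)on2)cc1` gives 31800 nM
compound 2 `COc1cc(-c2cc(CN(c3ncccn3)c3nc4ccccc4s3)on2)cc(OC)c1OC` gives 28400 nM

Compound 1 holds the higher of the two numbers, yet compound 2 lies within the usual scatter of it, so the two cannot be told apart. Compound 3 `Brc1ccc(-c2cc(CN(c3ncccn3)c3nc4ccccc4s3)on2)cc1` is derived from compound 1 by bromo in place of trifluoromethoxy on an aromatic carbon. Among the compounds with values here, no measured pair covers this change. Since compound 1 gives 31800 nM and nothing shown points either way, the step of a 1.1-fold lower number from compound 1 to compound 3 (0.03 log units; within the scatter) is expected to stay within the scatter, with no direction to expect. Compound 3 is accordingly estimated at 30000 nM, within a range of 12000 nM to 75000 nM.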

Compound 3, half-maximal inhibitory concentration: 31500 nM
Compound 3: middle estimate off by 1.1-fold (0.02 log units), on the low side, within the range that was stated.
By their numbers in this assay, from the lowest: compounds 2, 3 and 1 (each within the scatter of the next).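

In this assay, bromo in place of trifluoromethoxy gives a 1.0-fold lower number from compound 1 to compound 3 (0.00 log units; within the scatter), so at this position on the aromatic ring the exchange stays within the scatter, although the group that enters has 1 heavy atom against 5 for the group that leaves. The change also removes the 1 hydrogen-bond acceptor of the trifluoromethoxy group without a readable shift in the number. Nothing shown explains this result. On these data alone, whether an amine or a carboxylic acid at this position would move the number remains open, as does the effect of any change to the shared core.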